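A few compounds are considered here, and "the series" means these few. Any claim that something is new, unique, unknown or untested is made for them only; others in the source may bear on it.

Compound 1, `Cc1nc(N2CCN(C(=O)COc3ccc(Cl)cc3)CC2)c2cc(F)sc2n1`: 3390 nM
Compound 2, `Nc1nc(N2CCN(C(=O)COc3ccc(Cl)cc3)CC2)c2cc(F)sc2n1`: 700 nM
Compound 3, `Nc1nc(N2CCN(C(=O)COc3ccc(Cl)cc3)CC2)c2ccsc2n1`: 330 nM

In a functional assay on cells (Lymphocyte) (a higher number here means a weaker inhibitor, a lower number a stronger inhibitor), compound 3 holds the lowest number of the three; the gap to its nearest neighbour is a 2.1-fold lower number from compound 2 to compound 3 (0.33 log units; beyond the scatter), and compound 1, the furthest, gives 3390 nM. Compound 4, `Nc1nc(N2CCN(C(=O)COc3ccc(F)cc3)CC2)c2ccsc2n1`, differs from compound 3 by fluoro in place of chloro on an aromatic carbon. Neither measured step touches this part of the molecule: a 4.8-fold lower number from compound 1 to compound 2 (0.69 log units; beyond the scatter) and a 2.1-fold lower number from compound 2 to compound 3 (0.33 log units; beyond the scatter) both concern the shared core. Going by the values given here, no measured pair therefore bears on the change directly, and with nothing to suggest a large effect, a small step in this assay, at most slightly toward a higher number, is expected. Compound 4 is estimated at 500 nM, within 200 nM to 1300 nM, a step of a 1.5-fold higher number from compound 3 to compound 4 (0.18 log units; within the scatter) that is expected to stay near the scatter.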

Compound 4, half-maximal inhibitory concentration: 66 nM
Estimate against measurement, compound 4: 7.6-fold (0.88 log units) above; the whole stated range lies above it.
By their numbers in this assay, from the lowest: compound 4; then compound 3; then compound 2; then compound 1.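

In this assay, the 4-chlorophenoxy to 4-fluorophenoxy change gives (a 5.0-fold lower number from compound 3 to compound 4 (0.70 log units; beyond the scatter)). Going by these compounds alone, this shows that the far end of the molecule, which no earlier step touched, is sensitive to a single-atom swap. That step is about as large as the change on the shared core (a 4.8-fold lower number from compound 1 to compound 2 (0.69 log units; beyond the scatter)). Nothing available explains why this swap has such an effect. Still open, as far as these compounds go, is whether hydrogen, methyl, methoxy or a nitrile at this place would give a lower number, and whether the same swap would act similarly with the fluoro group of compound 2 present.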